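Cytotoxicity of a fourth analogue, set against three limits

A few compounds are considered here, and "the series" means these few. Any claim that something is new, unique, unknown or untested is made for them only; others in the source may bear on it.

Compound 1, `Cc1cc(-c2ccc3[nH]ccc3c2)cn2c(CSCCc3ccccc3)cnc12`: in an ADME assay on HEL cells (Homo sapiens) for cytotoxicity, with a stated time of 3 days (a lower number here means that less compound is tolerated, a higher number that more compound is tolerated), compound 1 gives >= 20 ug/mL, a limit of the assay.
Compound 2, `Cc1cc(-c2ccoc2)cn2c(CSCCc3ccccc3)cnc12`: in this assay compound 2 gives > 4 ug/mL, a limit of the assay.
Compound 3, `Cc1cc(-n2ccc3ccccc32)cn2c(CSCCc3ccccc3)cnc12`: in this assay compound 3 gives > 20 ug/mL, a limit of the assay.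

Compound 3 stands at a limit, and the other two values shown are limits as well; no value in this set is a number. The three values sit at the limit of > 20 ug/mL in this assay, at which 1 of the 3 values shown sits, the limit of > 4 ug/mL in this assay, at which 1 of the 3 values shown sits, and (the limit of >= 20 ug/mL in this assay, at which 1 of the 3 values shown sits). The step that the two limits leave unreadable from compound 1 to compound 3 is unreadable, as is a step that the two limits leave unreadable from compound 2 to compound 3, and a step that the two limits leave unreadable from compound 1 to compound 2 likewise. The shared core of compound 3 carries, on the place described, a group that compound 4, `Cc1cc(Sc2ccc(Cl)cc2)cn2c(CSCCc3ccccc3)cnc12`, replaces: (4-chlorophenyl)sulfanyl in place of 1H-indol-1-yl on an aromatic carbon. Within the data shown here, none of the measured steps is readable, so none of them gives a size or direction to carry over. Compound 4 is therefore expected to sit where the measured compounds sit, most likely at a limit again, with an estimated value of 20 ug/mL, between 8 ug/mL and 50 ug/mL. That estimate means a step of a number no higher from compound 3 to compound 4 (the limit leaves the size open) is expected, which is no step beyond the scatter.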

Compound 4, minimum cytotoxic concentration: 20 ug/mL
Estimate against measurement, compound 4: no gap at the digits printed; low and high end bracket the measured number.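

In this assay compound 4 gives 20 ug/mL as an actual number, the first at this position rather than a limit of the assay. With (4-chlorophenyl)sulfanyl in place of 1H-indol-1-yl the result is a number no higher from compound 3 to compound 4 (the limit leaves the size open) and, in place of 1H-indol-5-yl, it is a number no higher from compound 1 to compound 4 (the limit leaves the size open); neither these steps nor the step from compound 2 to compound 4 can be read for size. Nothing measured here bears on why compound 4 takes this value.

Still open, going by these compounds, is whether the sulfur or the chlorine goes with this number, which a plain phenylsulfanyl group or a 4-aminophenylsulfanyl group at this place could separate. On these data alone, compound 1, compound 2 and compound 3 also remain at limits, so where their true values lie against compound 4 stays open.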